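Oxetanyl amine in place of an oxanyl amide

This account rests on a few compounds, and the source may have more. Where it says the series, first, only, none or still open, it means among the compounds named here.

Measured so far:
- compound 1 `CC(=O)NCc1cccc(Cn2nc(NS(=O)(=O)c3ccc(Cl)s3)c3c(O)cccc32)c1` — 12.6 nM
- compound 2 `COc1cccc2c1c(NS(=O)(=O)c1ccc(Cl)s1)nn2Cc1cccc(CNC(=O)C2CCOCC2)c1` — 31.6 nM

Both compounds were tested in a functional assay on CHO cells for antagonist activity at C-C chemokine receptor type 4 (Homo sapiens), read by GTPgammaS binding; on this read-out higher numbers stand for weaker inhibition and lower numbers for stronger inhibition. Compound 1 gives 12.6 nM. Compound 2, with the higher of the two numbers, gives 31.6 nM; its nearest neighbour is compound 1, and the gap between them lies beyond the scatter. No step between measured compounds differing in a single place is available, so nothing can be said about the cause of that gap.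

Compound 3 `COc1cccc2c1c(NS(=O)(=O)c1ccc(Cl)s1)nn2Cc1cccc(CNC2COC2)c1` is not yet measured. It differs from compound 2 in one place: oxetan-3-yl in place of (oxan-4-yl)carbonyl on an amine nitrogen. Among the measured compounds shown here, no comparable step exists among the measured compounds. The size of this change is therefore uncertain. Compound 3 is expected to land at roughly a 1.6-fold higher number from compound 2 to compound 3 (0.20 log units; within the scatter), about the same or slightly weaker than compound 2. The estimate for compound 3 is 50 nM, within a range from 15 nM to 160 nM.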

Compound 3, half-maximal inhibitory concentration: 251 nM
Compound 3: middle estimate off by 5.0-fold (0.70 log units), on the low side; measured number outside the range, above it.
By their numbers in this assay, from the lowest: compound 1; then compound 2; then compound 3.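

In this assay, oxetan-3-yl in place of (oxan-4-yl)carbonyl on the amine nitrogen gives a 7.9-fold higher number from compound 2 to compound 3 (0.90 log units; beyond the scatter), which means weaker inhibition. Among the compounds shown here, this is the first comparison here that differs in one place only, and it shows that the group on this nitrogen matters: the amide of compound 2 cannot be exchanged for the smaller oxetanyl amine of compound 3 without loss. Nothing measured here explains the loss.

The step changes two things at once, as the carbonyl goes and the six-membered ring becomes a four-membered one, so the compounds shown cannot say which of the two counts. An oxan-4-yl group on the same amine nitrogen, or an (oxetan-3-yl)carbonyl group, would each change only one of them.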